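Adding a methyl to the amine of compound 1

This account rests on a few compounds, and the source may have more. Where it says the series, first, only, none or still open, it means among the compounds named here.

Compound 1 `NCC1(c2cccc3ccccc23)CCCCC1`: 6040 nM
Compound 2 `NCC1(c2ccc3ccccc3c2)CCCCC1`: 83 nM

Of the compounds shown here, two have been measured in an assay on isolated protein for inhibition of sodium-dependent dopamine transporter (Homo sapiens); a lower number here means a stronger inhibitor, a higher number a weaker inhibitor. Compound 1 gives 6040 nM, the higher of the two numbers, so it is the weaker inhibitor of the pair. Compound 2 gives 83 nM, a far lower number, and the gap between the two lies well beyond the scatter of repeated measurements. Among the compounds with values here, the two differ in which position of the shared bicyclic aromatic group is attached to the core, and no single step between them is counted here, so only their two values speak.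

Compound 3 `CNCC1(c2cccc3ccccc23)CCCCC1` has not been measured yet. It is derived from compound 1 by a small change: methyl in place of hydrogen on an amine nitrogen. Within the data shown here, no step of this kind between measured compounds is available, so there is nothing in this set to calibrate it. From general experience with such amines, a change of this size is expected to move this assay only modestly, most likely toward a somewhat lower number, though a result within the scatter would not surprise. For compound 3 the expected value is 3000 nM, with a plausible range from 800 nM to 12000 nM. This estimate means a step of a 2.0-fold lower number from compound 1 to compound 3 (0.30 log units; within the scatter).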

Compound 3, half-maximal inhibitory concentration: 1780 nM
Estimate against measurement, compound 3: 1.7-fold (0.23 log units) above; the measured number falls inside the stated range.
By their numbers in this assay, from the lowest: compound 2; then compound 3; then compound 1.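

In this assay, putting a methyl in place of hydrogen on the amine nitrogen gives a clear but modest change (a 3.4-fold lower number from compound 1 to compound 3 (0.53 log units; beyond the scatter)). Within the data shown here, this is the first sign of how this nitrogen responds to substitution: it can carry one added carbon without inhibition being lost, and on the core of compound 1 the number moves toward stronger inhibition by more than the usual scatter. Nothing available explains why this small addition lowers the number, so the step stands as an observation only.

Going by these compounds, it remains open whether a dimethylamino group, with a second methyl on the same nitrogen, or a longer group such as ethyl would lower the number further or reverse the gain. On these data alone, it is also open whether the same methyl would produce a step of similar size and direction on compound 2, since this single step on compound 1 cannot show whether the effect carries over to a compound whose bicyclic aromatic group is attached differently.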